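Ring size on the imidazole nitrogen: cyclopentyl to cycloheptyl

The compounds below may be only part of what the source reports. "The series", "measured", "known", "first", "only" and "open" are said of these compounds alone.

Compound 1 `CC(C)c1onc(-c2c(Cl)cccc2Cl)c1COc1ccc(-c2nc3ccc(C(=O)O)cc3n2CC(C)(C)C)cc1` gives 24.8 nM in an assay on isolated protein for agonist activity at Bile acid receptor (Homo sapiens), read by TR-FRET; on this read-out higher numbers stand for an effect only at larger amounts of compound and lower numbers for an effect already at smaller amounts. Compound 2 `CC(C)c1onc(-c2c(Cl)cccc2Cl)c1COc1ccc(-c2nc3ccc(C(=O)O)cc3n2C2CCCC2)cc1` carries cyclopentyl at the same position; in this assay compound 2 gives "not determined" (no result reported), so no number stands for it. Compound 3 `CC(C)c1onc(-c2c(Cl)cccc2Cl)c1COc1ccc(-c2nc3ccc(C(=O)O)cc3n2C2CCCCCC2)cc1` differs from compound 2 by cycloheptyl in place of cyclopentyl on an aromatic nitrogen. Within the data shown here, with no measured step for this change, the expectation in this assay is for a shift no larger than the scatter, with a slight lean toward weaker potency. Compound 3 is estimated at 40 nM, expected between 8 nM and 200 nM.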

Compound 3, half-maximal effective concentration: 113 nM
For compound 3 the middle estimate is 2.8-fold (0.45 log units) below the measured one; measured number inside the range.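

In this assay the aromatic nitrogen keeps activity with a seven-membered carbon ring, but a 4.6-fold higher number from compound 1 to compound 3 (0.66 log units; beyond the scatter) places cycloheptyl behind neopentyl at this position. The step from compound 2 to compound 3 cannot be read, so these values say nothing about ring size alone. No evidence at hand explains the difference between neopentyl and cycloheptyl. Open, on these data alone, is how cyclohexyl on the same nitrogen compares with cycloheptyl. Also open, as far as these compounds go, is whether a ring carrying an amine, such as piperidinyl, keeps activity there.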